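A few compounds are considered here, and "the series" means these few. Any claim that something is new, unique, unknown or untested is made for them only; others in the source may bear on it.

In a functional assay on A549 cells (Homo sapiens) for cytotoxicity, read by MTT assay, with a stated time of 4 days (a lower number here means a stronger inhibitor, a higher number a weaker inhibitor), the three measured compounds read as follows:

compound 1 `C=C1C(=O)[C@]23C[C@@]1(O)CC[C@H]2c1ccc(OS(=O)(=O)c2ccc(C)cc2)c(C)c1[C@@H]3Cn1cc(-c2ccc(Br)cc2)nn1`: 1630 nM
compound 2 `C=C1C(=O)[C@]23C[C@@]1(O)CC[C@H]2c1ccc(OS(=O)(=O)c2ccc(C)cc2)c(C)c1[C@@H]3Cn1cc(-c2ccc(F)cc2)nn1`: 1950 nM
compound 3 `C=C1C(=O)[C@]23C[C@@]1(O)CC[C@H]2c1ccc(OS(=O)(=O)c2ccc(C)cc2)c(C)c1[C@@H]3Cn1cc(-c2ccc(C)cc2)nn1`: 1830 nM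

Compound 3 sits in the middle of a tight cluster. Its nearest neighbour is compound 2, with a 1.1-fold lower number from compound 2 to compound 3 (0.03 log units; within the scatter); its furthest is compound 1, with a 1.1-fold higher number from compound 1 to compound 3 (0.05 log units; within the scatter). Neither gap rises above the scatter, so the three numbers are best read as one value.

Compound 4 `C=C1C(=O)[C@]23C[C@@]1(O)CC[C@H]2c1ccc(OS(=O)(=O)c2ccc(C)cc2)c(C)c1[C@@H]3Cn1cc(-c2ccc(OC)cc2)nn1` differs from compound 3 in one place: methoxy in place of methyl on an aromatic carbon.

All three measured steps bear on this change, since each of them also swaps the group on that same para position of the phenyl on the triazole: a 1.2-fold higher number from compound 1 to compound 2 (0.08 log units; within the scatter), a 1.1-fold higher number from compound 1 to compound 3 (0.05 log units; within the scatter) and a 1.1-fold lower number from compound 2 to compound 3 (0.03 log units; within the scatter). Bromo, fluoro and methyl at that position gave numbers that could not be told apart. Nothing in the series shows that position moving the read-out in this assay, and the methoxy is the fourth small group to be placed there.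

The step from compound 3 to compound 4 is therefore expected to stay within the scatter, a 1.0-fold lower number from compound 3 to compound 4 (0.01 log units; within the scatter). Compound 4 is estimated at 1800 nM, with a range from 900 nM to 3600 nM.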

Compound 4, half-maximal inhibitory concentration: 1470 nM
For compound 4 the middle estimate is 1.2-fold (0.09 log units) above the measured one; the range from low to high includes it.
By their numbers in this assay, from the lowest: compounds 4, 1, 3 and 2 (each within the scatter of the next).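

In this assay, the 4-methylphenyl to 4-methoxyphenyl change brings an oxygen and one counted hydrogen-bond acceptor onto the aromatic carbon para to a large group, and the read-out still does not separate, with a 1.2-fold lower number from compound 3 to compound 4 (0.10 log units; within the scatter) against the methyl analogue. The same holds against the two halogen analogues, with a 1.3-fold lower number from compound 2 to compound 4 (0.12 log units; within the scatter) and a 1.1-fold lower number from compound 1 to compound 4 (0.04 log units; within the scatter) all within the scatter, so compound 1, compound 2, compound 3 and compound 4 now form a single cluster of four different groups at this position, and the added oxygen gives no measurable separation. The data in hand offer no independent measurement that could account for this flat behaviour.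

The compounds shown leave open whether a group of another kind at this position, such as a primary amine, a carboxylic acid or a longer alkyl chain, would move the number out of this cluster. They also leave open how much the shared core contributes to the read-out, since it is identical in all four compounds and the only variation lies in this one substituent.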